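This account rests on a few compounds, and the source may have more. Where it says the series, first, only, none or still open, it means among the compounds named here.

Measured compounds in an ADME assay on HEL cells (Homo sapiens) for cytotoxicity, with a stated time of 3 days; on this read-out higher numbers stand for lower toxicity in this test and lower numbers for higher toxicity in this test:
- compound 1, `Cc1cc(-c2ccsc2)cn2c(CSCCc3ccccc3)cnc12`: >= 4 ug/mL
- compound 2, `Cc1cc(Br)cn2c(CSCCc3ccccc3)cnc12`: >= 2 ug/mL
- compound 3, `Cc1cc(-c2ccccc2O)cn2c(CSCCc3ccccc3)cnc12`: 100 ug/mL

Compound 1 gives >= 4 ug/mL, which is a limit of this assay, not a number. Compound 2 gives >= 2 ug/mL, which is likewise a limit. Compound 3 alone gives a number, 100 ug/mL; it is the only number shown. The steps a step that the two limits leave unreadable from compound 1 to compound 2, a step that the limit leaves unreadable from compound 1 to compound 3 and a step that the limit leaves unreadable from compound 2 to compound 3 are therefore not readable in size, since one end of each sits at the limit of >= 2 ug/mL in this assay, at which 1 of the 3 values shown sits, or (the limit of >= 4 ug/mL in this assay, at which 1 of the 3 values shown sits).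

Compound 4, `Cc1cc(-c2cccc(O)c2)cn2c(CSCCc3ccccc3)cnc12`, differs from compound 3 by 3-hydroxyphenyl in place of 2-hydroxyphenyl on an aromatic carbon. Among the measured compounds shown here, no measured step bears directly on this change, so no size beyond the scatter is expected in this assay. Compound 4 is estimated at 70 ug/mL, within 25 ug/mL to 100 ug/mL. The step of a 1.4-fold lower number from compound 3 to compound 4 (0.15 log units; within the scatter) expected here is essentially flat.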

Compound 4, minimum cytotoxic concentration: 20 ug/mL
Compound 4: middle estimate off by 3.5-fold (0.54 log units), on the high side; the whole stated range lies above it.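

In this assay, the aromatic carbon of the shared core tolerates no free change of hydroxy placement: 3-hydroxyphenyl in place of 2-hydroxyphenyl gives a 5.0-fold lower number from compound 3 to compound 4 (0.70 log units; beyond the scatter), with the same atoms and the same counts of donors and acceptors on both groups. The lower number here stands for higher toxicity in this test, and nothing at hand accounts for the shift. The steps from compound 1 and compound 2 to compound 4 cannot be read, since the values of compound 1 and compound 2 are limits of the assay.

Open, as far as these compounds go, is how 4-hydroxyphenyl, or methoxyphenyl or aminophenyl at the same carbon, would compare with compound 3 and compound 4. Also open, from the compounds shown here alone, is where thiophen-3-yl and bromo truly fall relative to either hydroxyphenyl group.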